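The source may hold more compounds than are shown below. What is called first, only, known or untested is meant among the compounds shown, and "the series" means these compounds.

Measured so far:
compound 1 `Cc1cccc(S(=O)(=O)c2ccc(CNC(=O)c3cc4cnccc4[nH]3)cc2)c1`: 32%
compound 2 `O=C(NCc1ccc(S(=O)(=O)N2CCCCC2)cc1)c1cc2ccncc2[nH]1`: "below limit of detection" (no number reported)
compound 3 `O=C(NCc1ccc(S(=O)(=O)c2ccccc2)cc1)c1cc2ccncc2s1`: 21%

In an ADME assay on microsomes from liver (Mus musculus) for metabolic stability, read by LC-MS, with a stated time of 30 min, tested at 1 uM (a lower number here means that less of the compound is left, a higher number that more of the compound is left), compound 3 gives 21%, the lowest of the two numbers recorded in the series. Compound 1 gives 32%, a number higher than that of compound 3 by more than the usual scatter. Compound 2 returned "below limit of detection" (no number reported), an entry for which no single number was reported.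

Compound 4 `O=C(NCc1ccc(S(=O)(=O)c2ccccc2)cc1)c1ccc2nccn2c1` is the next entry to be measured in this assay. It differs from compound 3 in one place:
a group of 9 heavy atoms (7 carbon, 2 nitrogen; one five-membered aromatic ring with 2 hetero atoms, one six-membered aromatic ring with 1 hetero atom) in place of a group of 9 heavy atoms (7 carbon, 1 nitrogen, 1 sulfur; one five-membered aromatic ring with 1 hetero atom, one six-membered aromatic ring with 1 hetero atom), on a carbonyl carbon

Among the compounds with values here, no step between two measured compounds is available for this kind of change, so the size of the move from compound 3 to compound 4 cannot be read off the series. Two of the three measured compounds sit low in this assay, and nothing in the series points to a large shift in either direction. The step implied by the estimate, a number 4 percentage points higher from compound 3 to compound 4 (within the scatter), is expected to stay within the scatter. For compound 4 the expected value in this assay is 25%, with a range from 8% to 45%.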

Compound 4, percent of the compound remaining: 18%
Beside the measured number, compound 4's estimate is 7 percentage points above it; low and high end bracket the measured number.
By their numbers in this assay, from the lowest: compounds 4 and 3 (each within the scatter of the next); then compound 1.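

In this assay, within the data shown here, exchanging the group on the carbonyl carbon gives a number 3 percentage points lower from compound 3 to compound 4 (within the scatter), the first one-place step. On a carbonyl carbon whose other neighbours are: amide-type nitrogen, a group with a five-membered aromatic ring with 2 hetero atoms and one with a five-membered aromatic ring with 1 hetero atom are therefore not told apart by the percent of compound remaining, so this exchange of sulfur for nitrogen gives no separation in this series. No measured data bearing on the reason for this result are available for these compounds.

Among these compounds, compound 1 and compound 2 each differ from compound 4 in more than one place, so they add no step at this position. As far as these compounds go, whether a carboxylic acid or a short amine chain on the carbonyl carbon would give a step beyond the scatter remains open.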